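A repeated dichlorophenyl swap on a shared core

The source may report more compounds than this note shows. Statements on the series, on what has been measured and on what is new or still open speak of the compounds shown alone.

Three compounds built on one shared core were tested in a functional assay on MKN-74 cells (Homo sapiens) for antiproliferative activity, with a stated time of 24 h; a lower number here means a stronger inhibitor, a higher number a weaker inhibitor. Compound 1, `NC(=O)c1c(NC(=O)c2ccc(C(F)(F)F)cc2)sc2c1CCN(Cc1c(Cl)cccc1Cl)C2`, gives 8530 nM. Compound 2, `NC(=O)c1c(NC(=O)c2ccc(C(F)(F)F)cc2)sc2c1CCN(Cc1ccc(Cl)cc1Cl)C2`, gives 10900 nM. Compound 3, `Cc1ccc(C(=O)Nc2sc3c(c2C(N)=O)CCN(Cc2c(Cl)cccc2Cl)C3)cc1`, gives 12300 nM. Compound 2 differs from compound 1 by 2,4-dichlorophenyl in place of 2,6-dichlorophenyl on a saturated chain carbon bound to an amine nitrogen in a ring, and the step is a 1.3-fold higher number from compound 1 to compound 2 (0.11 log units; within the scatter). Compound 3 differs from compound 1 by methyl in place of trifluoromethyl on an aromatic carbon, with a step of a 1.4-fold higher number from compound 1 to compound 3 (0.16 log units; within the scatter). All three values therefore sit within the usual scatter of one another, and no order among them can be read.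

Compound 4, `Cc1ccc(C(=O)Nc2sc3c(c2C(N)=O)CCN(Cc2ccc(Cl)cc2Cl)C3)cc1`, has not yet been measured. It differs from compound 3 by 2,4-dichlorophenyl in place of 2,6-dichlorophenyl on a saturated chain carbon bound to an amine nitrogen in a ring, the same change that separates compound 1 from compound 2. Because that earlier change gave a 1.3-fold higher number from compound 1 to compound 2 (0.11 log units; within the scatter), a step of comparable size is expected from compound 3 to compound 4, namely a 1.3-fold higher number from compound 3 to compound 4 (0.10 log units; within the scatter), starting from compound 3 at 12300 nM. On that basis compound 4 is estimated at 15500 nM in this assay, with a likely range from 7500 nM to 32000 nM.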

Compound 4, half-maximal inhibitory concentration: 25500 nM
For compound 4 the middle estimate is 1.6-fold (0.22 log units) below the measured one; low and high end bracket the measured number.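

In this assay, 2,4-dichlorophenyl in place of 2,6-dichlorophenyl gives a 2.1-fold higher number from compound 3 to compound 4 (0.32 log units; beyond the scatter), and this step does not differ measurably from the earlier one: the same change on two cores in this assay, a 1.3-fold higher number (0.11 log units; within the scatter) from compound 1 to compound 2 and a 2.1-fold higher number (0.32 log units; beyond the scatter) from compound 3 to compound 4, 1.6-fold (0.21 log units) apart, within the scatter of two such steps

Methyl in place of trifluoromethyl gives a 2.3-fold higher number from compound 2 to compound 4 (0.37 log units; beyond the scatter), and this step also agrees with its earlier counterpart: the same change on two cores in this assay, a 1.4-fold higher number (0.16 log units; within the scatter) from compound 1 to compound 3 and a 2.3-fold higher number (0.37 log units; beyond the scatter) from compound 2 to compound 4, 1.6-fold (0.21 log units) apart, within the scatter of two such steps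

Each change therefore carries across these two cores without a detectable difference in step size, although only the newer step of each pair lies beyond the scatter, so neither change has a step beyond the scatter on both cores; this does not show that either step is larger on one core than on the other, nor that the same would hold on any further core in the series.

The compounds shown leave open how an unsubstituted benzyl group would compare with the two dichlorobenzyl groups on the shared core. They also leave open whether a carboxylic acid or an amine in place of the methyl or trifluoromethyl would follow the same steps.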